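This account rests on a few compounds, and the source may have more. Where it says the series, first, only, none or still open, it means among the compounds named here.

Within the data shown here, in a functional assay on DU-145 cells (Homo sapiens) for cytotoxicity, read by MTT assay, with a stated time of 48 h (a lower number here means a stronger inhibitor, a higher number a weaker inhibitor), compound 1 (`CC(C)n1c(/C=C2/C(=O)Nc3ccc(Br)cc32)nc2ccccc21`) gives 7500 nM and so holds the lower of the two numbers measured so far, which makes it the stronger of the pair. Compound 2 (`CC(C)n1c(/C=C2/C(=O)Nc3ccc(F)cc32)nc2ccccc21`) gives 24500 nM with fluoro in place of bromo on an aromatic carbon. Among the measured compounds shown here, the only measured step is a 3.3-fold higher number from compound 1 to compound 2 (0.51 log units; beyond the scatter) and it is modest. Compound 3 (`Cn1c(/C=C2/C(=O)Nc3ccc(Br)cc32)nc2ccccc21`) keeps the bromo group of compound 1 but has methyl in place of isopropyl on an aromatic nitrogen next to the ring atom that bears a large group. For the measured compounds named here, no tested pair varies the group on this nitrogen, so the bromo-to-fluoro step is only a rough guide to how far a single change can move the number. A step of similar modest size in this assay is expected towards a higher number, although the direction is a judgement and a step within the scatter remains possible. For compound 3 the estimated value is 16000 nM with an expected range from 6000 nM to 40000 nM in this assay. This estimate means an expected step of a 2.1-fold higher number from compound 1 to compound 3 (0.33 log units; beyond the scatter) overall.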

Compound 3, half-maximal inhibitory concentration: 39600 nM
Compound 3: the middle estimate sits 2.5-fold (0.39 log units) below what was measured, within the range that was stated.
By their numbers in this assay, from the lowest: compound 1; then compounds 2 and 3 (each within the scatter of the next).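

Methyl in place of isopropyl on the aromatic nitrogen, with the bromo group kept, gives a 5.3-fold higher number from compound 1 to compound 3 (0.72 log units; beyond the scatter) in this assay. Among these compounds, this is the first tested change at this nitrogen, and it shows that the group here affects the read-out, with the isopropyl compound giving the lower number of this pair. Compound 1, whose steps to both other compounds lie beyond the scatter, remains the strongest of the three, and no measurement shown here accounts for the change at this nitrogen.

From the compounds shown here alone, with only isopropyl and methyl tested at this place, it remains open whether a longer chain such as butyl, a ring-bearing group such as benzyl, or a chain ending in an amine would give a lower or a higher number than compound 1. Going by these compounds, it also remains open whether methyl in place of isopropyl would move the number in the same direction and by a similar amount if fluoro stood in place of bromo on the shared core.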